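A few compounds are considered here, and "the series" means these few. Any claim that something is new, unique, unknown or untested is made for them only; others in the source may bear on it.

Measured in an ADME assay on Caco-2 cells (Homo sapiens) for permeability, in the apical to basolateral direction; on this read-out lower numbers stand for lower permeability and higher numbers for higher permeability:
Compound 1 `Cn1cncc1CN1CC(N(CC2CCN(C(=O)c3ccccc3)CC2)S(=O)(=O)c2ccccn2)Cc2cc(C#N)ccc21`: 0.5 10^-6 cm/s
Compound 2 `CCC(=O)N1CCC(CN(C2Cc3cc(C#N)ccc3N(Cc3cncn3C)C2)S(=O)(=O)c2ccccn2)CC1`: 0.5 10^-6 cm/s

Among the compounds with values here, compound 2 stands level with compound 1 in this assay, the only neighbour measured so far. Compound 3 `Cn1cncc1CN1CC(N(CC2CCN(C(=O)c3ccco3)CC2)S(=O)(=O)c2ccccn2)Cc2cc(C#N)ccc21` differs from compound 2 by a single change: furan-2-yl in place of ethyl on a carbonyl carbon. Within the data shown here, only one measured step bears on this, and it also swapped the group on the carbonyl carbon: no change at the digits printed from compound 1 to compound 2 (within the scatter), within the scatter. Because no change at the digits printed from compound 1 to compound 2 (within the scatter) left the read-out unchanged, the expected step is no change at the digits printed from compound 2 to compound 3 (within the scatter), again within the scatter. Compound 3 is estimated at 0.5 10^-6 cm/s, with a range from 0.25 10^-6 cm/s to 1 10^-6 cm/s.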

Compound 3, apparent permeability: 0.5 10^-6 cm/s
For compound 3 middle estimate and measured number coincide at the digits printed; low and high end bracket the measured number.
By their numbers in this assay, from the lowest: compounds 1, 2 and 3 (each within the scatter of the next).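

In this assay, furan-2-yl on the carbonyl carbon brings a five-membered aromatic ring and a hydrogen-bond acceptor, yet the result is no change at the digits printed from compound 2 to compound 3 (within the scatter) and, set against phenyl, no change at the digits printed from compound 1 to compound 3 (within the scatter) as well. At this position, then, ethyl, phenyl and furan-2-yl all read alike, so a third group, with a ring oxygen, joins the two already level. Nothing at hand explains this flat result. On these data alone, whether an amine or a carboxylic acid on that carbonyl carbon would shift the number stays open. So does whether replacing the nitrile on the shared core would.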